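Trifluoromethyl for Methyl on a Sulfonamide Inhibitor

The compounds below may be only part of what the source reports. "The series", "measured", "known", "first", "only" and "open" are said of these compounds alone.

Of the compounds shown here, three sharing one core have been measured so far. Compound 1 `O=C(/C=C/c1cccnc1)NCCCCCCc1ccc(S(=O)(=O)Nc2ccccc2)cc1` gives 48.5 nM in a functional assay on K562 cells (Homo sapiens) for inhibition, read by CCK-8 assay, with a stated time of 72 h; on this read-out higher numbers stand for weaker inhibition and lower numbers for stronger inhibition. Compound 2 `O=C(/C=C/c1cccnc1)NCCCc1cccc(S(=O)(=O)Nc2ccccc2)c1` gives 86.8 nM in this assay. Compound 3 `Cc1ccc(NS(=O)(=O)c2cccc(CCCCCCNC(=O)/C=C/c3cccnc3)c2)cc1` gives 2.98 nM in this assay, the lowest of the three numbers and thus the strongest inhibition in this set; its gaps to compound 1 and to compound 2 both lie beyond the usual scatter of repeated measurements.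

Compound 4 `O=C(/C=C/c1cccnc1)NCCCCCCc1cccc(S(=O)(=O)Nc2ccc(C(F)(F)F)cc2)c1` has not yet been measured. It differs from compound 3 in a single place: trifluoromethyl in place of methyl on an aromatic carbon. Among the measured compounds shown here, no pair of measured compounds differs in exactly one place, so no measured step shows how large such a swap tends to be in this assay. Compound 3 stands as the only direct reference point. A single exchange of this kind is expected to shift the number only a little, most likely slightly upward toward weaker inhibition, and quite possibly not beyond the scatter at all. The expected change in this assay is a 1.7-fold higher number from compound 3 to compound 4 (0.22 log units; within the scatter). Compound 4 is estimated at 5 nM in this assay, with a range from 1.5 nM to 20 nM.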

Compound 4, half-maximal inhibitory concentration: 44.9 nM
Beside the measured number, compound 4's estimate is 9.0-fold (0.95 log units) below it; the whole stated range lies below it.
By their numbers in this assay, from the lowest: compound 3; then compounds 4, 1 and 2 (each within the scatter of the next).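

The first step read in this series shows that this place on the molecule is far from neutral: exchanging methyl for trifluoromethyl on the aromatic ring, para to a large group, gives a 15-fold higher number from compound 3 to compound 4 (1.18 log units; beyond the scatter) in this assay and so costs much of the strong inhibition seen with the 4-methylphenyl group. The earlier compounds shown here could not show this, since no two of them differed in a single place, and their numbers could not separate the effect of this ring substituent from that of any other change. Among the compounds shown here, no measurement at hand bears on why this one exchange moves the number so far, so the step stands as an observation without an explanation.

For the compounds shown here, with only two groups compared at this place, it remains open whether a chlorine atom, a methoxy group or an amine there would behave more like methyl or more like trifluoromethyl. Going by these compounds alone, also open is whether the same exchange would shift the number as far in a compound with a shorter chain, such as the one in compound 2.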